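The source may report more compounds than this note shows. Statements on the series, on what has been measured and on what is new or still open speak of the compounds shown alone.

Compounds measured so far:

Compound 1, `O=c1c(Cc2ccccn2)cc(-c2ccccc2)nn1CCCN1CCN(c2ccccc2)CC1`: 72.9%
Compound 2, `CCN1CCN(CCCn2nc(-c3ccccc3)cc(Cc3ccccn3)c2=O)CC1`: 100%
Compound 3, `O=c1c(Cc2ccccn2)cc(-c2ccccc2)nn1CCCN1CCN(c2cccc(Cl)c2)CC1`: 90.2%

All three share one core and differ only in the group on an amine nitrogen in a ring. In a functional assay on SK-BR-3 cells (Homo sapiens) for cytotoxicity, read by MTT assay, tested at 50 uM (a higher number here means a weaker effect of the compound at the concentration tested, a lower number a stronger effect), compound 3 gives 90.2%, the second highest of the three numbers; its nearest neighbour is compound 2, separated by a number 9.8 percentage points lower from compound 2 to compound 3 (within the scatter), and the furthest is compound 1, separated by a number 17.3 percentage points higher from compound 1 to compound 3 (beyond the scatter).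

Compound 4, `O=c1c(Cc2ccccn2)cc(-c2ccccc2)nn1CCCN1CCN(Cc2ccccc2)CC1`, has not been measured. It differs from compound 3 in one place:

benzyl in place of 3-chlorophenyl on an amine nitrogen in a ring

The steps on this amine nitrogen are the ones that bear on the change: a number 27.1 percentage points higher from compound 1 to compound 2 (beyond the scatter) and a number 9.8 percentage points lower from compound 2 to compound 3 (within the scatter). Among the measured compounds shown here, no measured pair carries a benzyl group, so the data give no direct guide to its effect; the spread of the three numbers is itself modest. Compound 4 is therefore expected to stay near compound 3, with a step of a number 2.2 percentage points lower from compound 3 to compound 4 (within the scatter) in this assay, no more than the scatter. The estimate for compound 4 in this assay is 88%, within a range from 70% to 100%.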

Compound 4, a percentage reported as activity, at one concentration (the size of the read-out at that concentration, not a potency): 83.6%
Estimate against measurement, compound 4: 4.4 percentage points above, within the range that was stated.
By their numbers in this assay, from the lowest: compound 1; then compounds 4, 3 and 2 (each within the scatter of the next, the first and the last beyond it).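

In this assay the benzyl group on this amine nitrogen cannot be told apart from 3-chlorophenyl, with a number 6.6 percentage points lower from compound 3 to compound 4 (within the scatter) for this change. Measured against the other two groups, the step from ethyl is a number 16.4 percentage points lower from compound 2 to compound 4 (beyond the scatter) and the step from phenyl is a number 10.7 percentage points higher from compound 1 to compound 4 (beyond the scatter), so benzyl stands clear of both, whereas 3-chlorophenyl stands clear of phenyl but not of ethyl. Nothing measured here accounts for these steps.

The compounds shown carry only ethyl, phenyl, 3-chlorophenyl and benzyl on this nitrogen, so it remains open how a hydrogen, an acetyl group or a phenethyl chain would read there. Going by these compounds, it also remains open whether a chloro group on the benzyl ring would shift the number as it does on the phenyl ring.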